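The source may report more compounds than this note shows. Statements on the series, on what has been measured and on what is new or still open speak of the compounds shown alone.

Measured so far in a functional assay on SW480 cells (Homo sapiens) for antiproliferative activity, read by MTT assay, with a stated time of 48 h; on this read-out higher numbers stand for weaker inhibition and lower numbers for stronger inhibition:
- compound 1 `COC/C1=C/C[C@](C)(CCC=C(C)C)/C=C/[C@@H](OC(=O)C=C(C)C)[C@](C)(O)/C=C/C1=O` gives 3850 nM here
- compound 2 `CO[C@]1(C)/C=C/C(=O)/C(CO)=C\C[C@](C)(CCC=C(C)C)/C=C/[C@H]1OC(=O)C=C(C)C` gives 15200 nM here
- compound 3 `C=C1/C=C/C(=O)/C(CO)=C\C[C@](C)(CCC=C(C)C)/C=C/[C@H]1OC(=O)C=C(C)C` gives 2970 nM here

Compound 1 sits level with compound 3, within the scatter. Compound 2 gives a higher number than compound 1, beyond the scatter, and so weaker inhibition.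

The next compound is compound 4 `CC(C)=CCC[C@]1(C)/C=C/[C@@H](OC(=O)C=C(C)C)[C@](C)(O)/C=C/C(=O)/C(CN2CCN(C)CC2)=C\C1`, with the change 4-methylpiperazin-1-yl in place of methoxy on a saturated chain carbon bound to a double-bonded ring carbon from compound 1: 4-methylpiperazin-1-yl in place of methoxy on a saturated chain carbon bound to a double-bonded ring carbon. Among the compounds with values here, no measured pair differs in one place only, so nothing measured isolates this change.

The anchors are compound 1 at 3850 nM and compound 3 at 2970 nM, while compound 2 at 15200 nM shows that the series can move beyond the scatter. No step beyond the scatter is expected in this assay here: the estimated 1.3-fold lower number from compound 1 to compound 4 (0.11 log units; within the scatter) stays inside it, in the direction of slightly stronger inhibition. The wide range expresses that uncertainty. For compound 4 the estimate is 3000 nM, with an expected range from 900 nM to 10000 nM as the likely span.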

Compound 4, half-maximal inhibitory concentration: 800 nM
Beside the measured number, compound 4's estimate is 3.8-fold (0.57 log units) above it; the measured number lies below the stated range.
By their numbers in this assay, from the lowest: compound 4; then compounds 3 and 1 (each within the scatter of the next); then compound 2.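

In this assay, within the data shown here, 4-methylpiperazin-1-yl in place of methoxy on a saturated chain carbon bound to a double-bonded ring carbon gives a 4.8-fold lower number from compound 1 to compound 4 (0.68 log units; beyond the scatter), the first step that isolates a single change. The direction is towards stronger inhibition, so this position is not limited to a small ether and accepts a ring-bearing amine with a gain in this read-out. Nothing available here accounts for the gain.

This one step cannot separate the contribution of the piperazine ring from that of its methyl group; piperazin-1-yl without the methyl, morpholin-4-yl or open-chain dimethylamino at this position would begin to do so. On these data alone, whether the same replacement has a similar effect with the other groups carried by compound 2 or compound 3 also remains open.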